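An Ethynyl-to-Iodo Swap Carried Across Two Cores

This account rests on a few compounds, and the source may have more. Where it says the series, first, only, none or still open, it means among the compounds named here.

Compound 1 `C#Cc1cn([C@@H]2O[C@H](CO)[C@@H](O)[C@H]2O)c2nc(C)nc(N)c12` in a functional assay on HCT-116 cells (Homo sapiens), read by MTT assay, with a stated time of 72 h (on this read-out lower numbers stand for stronger inhibition and higher numbers for weaker inhibition), gives > 20000 nM, which is a limit of the assay and not a number.
Compound 2 `Cc1nc(N)c2c(I)cn([C@@H]3O[C@H](CO)[C@@H](O)[C@H]3O)c2n1` in this assay gives > 20000 nM, again only a limit.
Compound 3 `C#Cc1cn([C@@H]2O[C@H](CO)[C@@H](O)[C@H]2O)c2ncnc(OC)c12` in this assay gives 4060 nM.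

Compound 1 and compound 2 share one core and differ by iodo in place of ethynyl on an aromatic carbon. The step that the two limits leave unreadable from compound 1 to compound 2 cannot be read, because both values sit at the limit of > 20000 nM in this assay, at which 2 of the 3 values shown sit. Compound 3 carries another core; the difference between the two cores is not broken down here. Compound 4 `COc1ncnc2c1c(I)cn2[C@@H]1O[C@H](CO)[C@@H](O)[C@H]1O` arises from compound 3 by the same change, (iodo in place of ethynyl on an aromatic carbon). Since the earlier step gives no size, the expectation for compound 4 rests on compound 3 alone, whose value in this assay is 4060 nM. The step of a 1.2-fold higher number from compound 3 to compound 4 (0.09 log units; within the scatter) is therefore expected to stay small. Compound 4 is estimated at 5000 nM, with a range from 1200 nM to 20000 nM.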

Compound 4, half-maximal inhibitory concentration: > 20000 nM
Compound 4 ended at the assay's limit; the forecaster's own chance of this, stated with the estimate: 25%; middle value at least 4.0-fold (0.60 log units) from the limit.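

In this assay compound 4 gives > 20000 nM, which is a limit of the assay and not a number. Among these compounds, on the core of compound 3, iodo in place of ethynyl therefore brings an at least 4.9-fold higher number from compound 3 to compound 4 (0.69 log units; beyond the scatter), so on this core the ethynyl compound is the one with a readable value. Whether the change carries from one core to the other stays unshown, since the step on the core of compound 1 cannot be read and the step on the core of compound 3 has no upper end: the limit of > 20000 nM in this assay, at which 3 of the 4 values shown sit.

The compounds shown leave open how an amine, a nitrile or a longer chain on this aromatic carbon would read in this assay. Whether any such group would give a readable value on the core of compound 1 is open too.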